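Isopropylamino for cyclohexyl on the carbonyl: outlook for compound 4

This account rests on a few compounds, and the source may have more. Where it says the series, first, only, none or still open, it means among the compounds named here.

Three compounds have been run in an assay on isolated protein with Bile acid receptor (Homo sapiens) as the target; on this read-out lower numbers stand for an effect already at smaller amounts and higher numbers for an effect only at larger amounts of compound. Compound 1 `COC(=O)/C=C/c1cccc(N(Cc2ccc(/C=C/c3c(Cl)cccc3Cl)cc2)C(=O)C(C)C)c1` gives 195 nM, compound 2 `COC(=O)/C=C/c1cccc(N(Cc2ccc(/C=C/c3cccc(C(F)(F)F)c3)cc2)C(=O)NC(C)C)c1` gives 932 nM, and compound 3 `COC(=O)/C=C/c1cccc(N(Cc2ccc(/C=C/c3ccccc3F)cc2)C(=O)C2CCCCC2)c1` gives 64 nM. Compound 3 holds the lowest number; both gaps to it lie beyond the scatter, so compound 3 is the most potent so far, compound 1 nearer, compound 2 furthest. Compound 4 `COC(=O)/C=C/c1cccc(N(Cc2ccc(/C=C/c3ccccc3F)cc2)C(=O)NC(C)C)c1` keeps the fluorophenyl side of compound 3 and differs only in isopropylamino in place of cyclohexyl on a carbonyl carbon. Going by the values given here, no measured pair isolates this change; the only hint is compound 2, which also carries the isopropylcarbamoyl group and gives 932 nM, though its other side differs as well. A moderate rise in the number is expected, as a 5.5-fold higher number from compound 3 to compound 4 (0.74 log units; beyond the scatter). Compound 4 is estimated at 350 nM, with a range from 120 nM to 1000 nM.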

Compound 4, half-maximal effective concentration: 431 nM
For compound 4 the middle estimate is 1.2-fold (0.09 log units) below the measured one, within the range that was stated.
By their numbers in this assay, from the lowest: compound 3; then compound 1; then compound 4; then compound 2.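

On the carbonyl carbon, isopropylamino in place of cyclohexyl can now be read as a single change: a 6.7-fold higher number from compound 3 to compound 4 (0.83 log units; beyond the scatter) on the 2-fluorophenyl side. With the isopropylcarbamoyl group held fixed, 2-fluorophenyl in place of 3-(trifluoromethyl)phenyl also reads alone, as a 2.2-fold lower number from compound 2 to compound 4 (0.33 log units; beyond the scatter) in the same direction as the lead of compound 3. Nothing available bears on the reason for either step.

Going by these compounds alone, only one pair isolates the carbonyl change, so its size with other aryl groups stays open. A cyclohexylamino group on the same carbonyl carbon would separate the effect of the ring from that of the nitrogen.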